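The source may report more compounds than this note shows. Statements on the series, on what has been measured and on what is new or still open speak of the compounds shown alone.

Working notes on the series. Compound 1 `CC(C)(C)c1cc(OC(=O)c2ccco2)ccc1O` is read in an assay on isolated protein for antagonist activity at Bile acid receptor (Homo sapiens), read by HTRF, with a stated time of 30 min (on this read-out lower numbers stand for stronger inhibition and higher numbers for weaker inhibition), only as a limit, > 100000 nM. Compound 2 `CC(C)(C)c1cc(OC(=O)c2ccccc2)ccc1O` likewise returns only a limit in this assay, > 100000 nM. The step from one ester to the other, a step that the two limits leave unreadable from compound 1 to compound 2, is therefore not readable in size. For the measured compounds named here, compound 3 `CC(C)(C)c1cc(NC(=O)c2c(Cl)cc(NCc3ccncc3)cc2Cl)ccc1O` is the one member with a number: in this assay compound 3 gives 9800 nM, and it stands as the only measured value among the three, the other two sitting at the limit of > 100000 nM in this assay, at which 2 of the 3 values shown sit. Compound 4 `CC(C)(C)c1cc(NC(=O)c2c(Cl)cc(N3CCNCC3)cc2Cl)ccc1O` is not yet measured; it differs from compound 3 by piperazin-1-yl in place of ((pyridin-4-yl)methyl)amino on an aromatic carbon. Going by the values given here, no measured step touches this position: the single measured step lies between two limits and carries no size. The amide and the shared core of compound 3 are kept. With nothing to anchor a direction, the step from compound 3 to compound 4 is expected to be a 1.0-fold higher number from compound 3 to compound 4 (0.01 log units; within the scatter), within the scatter. Compound 4 is therefore estimated at 10000 nM, with a range from 3000 nM to 40000 nM.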

Compound 4, half-maximal inhibitory concentration: > 100000 nM
Compound 4 ended at the assay's limit; the forecaster's own chance of this, stated with the estimate: 15%; middle value at least 10-fold (1.00 log units) from the limit.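

In this assay, for the compounds shown here, this position gives the first step that can be read, an at least 10-fold higher number from compound 3 to compound 4 (1.00 log units; beyond the scatter), with piperazin-1-yl in place of ((pyridin-4-yl)methyl)amino. The position is therefore not indifferent to the group it carries: with the amide and the shared core kept, this one change is enough to lose the measurable inhibition of compound 3. The value of compound 4 is a limit and not a number, so the step has a lower bound but no full size: the limit of > 100000 nM in this assay, at which 3 of the 4 values shown sit.

The compounds shown leave open which part of ((pyridin-4-yl)methyl)amino matters, the pyridine ring or the amino link to the aromatic carbon. A benzylamino group would test the ring nitrogen, and a morpholin-4-yl group would test the second nitrogen of piperazin-1-yl.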